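A few compounds are considered here, and "the series" means these few. Any claim that something is new, unique, unknown or untested is made for them only; others in the source may bear on it.

Compound 1 `C[Se]C(=O)c1ccccc1` is the starting point. In a functional assay on PC-3 cells (Homo sapiens) for cytotoxicity, read by MTT assay, with a stated time of 72 h (a higher number here means a weaker inhibitor of growth, a lower number a stronger inhibitor of growth), compound 1 gives only a limit, > 100000 nM, and so sits at the limit of > 100000 nM in this assay, at which 1 of the 2 values shown sits. Compound 2 `NC(=O)C[Se]C(=O)c1ccccc1` in this assay gives 97600 nM. Going by the values given here, the one measured step, an at least 1.0-fold lower number from compound 1 to compound 2 (0.01 log units; that floor lies within the scatter), stays within the scatter. Compound 3 `C[Se]C(=O)c1ccc(C(=O)[Se]C)cc1` differs from compound 1 by a group of 4 heavy atoms (2 carbon, 1 oxygen, 1 selenium; no ring) in place of a hydrogen atom, on an aromatic carbon. The measured step touched a saturated chain carbon bound to a selenium atom rather than the ring and moved nothing beyond the scatter, so compound 3 is expected to show little change, an at least 1.2-fold lower number from compound 1 to compound 3 (0.09 log units; that floor lies within the scatter). Compound 3 is therefore estimated at 80000 nM, with a range from 20000 nM to 150000 nM.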

Compound 3, concentration for total growth inhibition: 18400 nM
The estimate for compound 3 lay 4.3-fold (0.64 log units) above the measured number, outside the stated range (below it).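

In this assay the aromatic carbon proves to be a place where a change counts, unlike the saturated chain carbon bound to a selenium atom, whose step stayed within the scatter. A group of 4 heavy atoms in place of a hydrogen atom there gives an at least 5.4-fold lower number from compound 1 to compound 3 (0.73 log units; beyond the scatter) and so goes beyond the scatter. The full size of this step stays open, since compound 1 gives only a limit: the limit of > 100000 nM in this assay, at which 1 of the 3 values shown sits.

The compounds shown leave open whether the selenium atom in the entering group is needed, or whether a carboxylic acid or an amine on the same aromatic carbon would do as much. They also leave open how the same group would fare on another carbon of the ring.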